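Changing the group on the ring nitrogen

The source may hold more compounds than are shown below. What is called first, only, known or untested is meant among the compounds shown, and "the series" means these compounds.

Of the compounds shown here, three sharing one core have been tested in a functional assay on HOS-TE85 cells (Homo sapiens) for inhibition, read by CCK-8 assay, with a stated time of 72 h; on this read-out lower numbers stand for stronger inhibition and higher numbers for weaker inhibition. Compound 1 (`O=C(NCCCCn1cccn1)c1cccc(C2SCC(=O)N2c2cccnc2)c1`), with pyridin-3-yl on the amide-type nitrogen in a ring, gives > 1000 nM, which is a limit of the assay and not a number. Compound 2 (`COc1ccccc1N1C(=O)CSC1c1cccc(C(=O)NCCCCn2cccn2)c1`) carries 2-methoxyphenyl there and gives 91.7 nM. Compound 3 (`CCOC(=O)c1sc(N2C(=O)CSC2c2cccc(C(=O)NCCCCn3cccn3)c2)nc1C`) carries 5-(ethoxycarbonyl)-4-methyl-1,3-thiazol-2-yl and gives 430 nM, the higher of the two actual numbers.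

Compound 4 (`O=C(NCCCCn1cccn1)c1cccc(C2SCC(=O)N2c2cccc(C3CC3)c2)c1`) has 3-cyclopropylphenyl in place of that group at the same nitrogen: 3-cyclopropylphenyl in place of 5-(ethoxycarbonyl)-4-methyl-1,3-thiazol-2-yl on an amide-type nitrogen in a ring.

All three measured steps change this one position. They show an at least 10-fold lower number from compound 1 to compound 2 (1.03 log units; beyond the scatter), a large step, then an at least 2.3-fold lower number from compound 1 to compound 3 (0.36 log units; beyond the scatter), at least a modest one, and a 4.7-fold higher number from compound 2 to compound 3 (0.67 log units; beyond the scatter), a modest one. The last is the closest guide, since compound 2 also has a six-membered aromatic ring of carbon only on this nitrogen, and it lies ahead of compound 3 by a 4.7-fold higher number from compound 2 to compound 3 (0.67 log units; beyond the scatter). Within the data shown here, no tested compound carries a cyclopropyl group, so the size of the step remains uncertain. A modest step downward is expected, namely a 2.9-fold lower number from compound 3 to compound 4 (0.46 log units; beyond the scatter). For compound 4 the estimated value is 150 nM, with an expected range from 40 nM to 600 nM.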

Compound 4, half-maximal inhibitory concentration: 299 nM
The estimate for compound 4 lay 2.0-fold (0.30 log units) below the measured number; measured number inside the range.
By their numbers in this assay, from the lowest: compound 2; then compounds 4 and 3 (each within the scatter of the next). At a limit, above all of these: compound 1.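

In this assay, replacing 5-(ethoxycarbonyl)-4-methyl-1,3-thiazol-2-yl with 3-cyclopropylphenyl gives a 1.4-fold lower number from compound 3 to compound 4 (0.16 log units; within the scatter), so a group with 4 hydrogen-bond acceptors and an all-carbon group with 0 cannot be told apart at this nitrogen. A six-membered aromatic ring of carbon only is also not enough on its own to match compound 2, the strongest compound shown: replacing 2-methoxyphenyl with 3-cyclopropylphenyl gives a 3.3-fold higher number from compound 2 to compound 4 (0.51 log units; beyond the scatter). Against pyridin-3-yl the change reads as an at least 3.3-fold lower number from compound 1 to compound 4 (0.52 log units; beyond the scatter), but this is only a bound, as the value for compound 1 is a limit and not a number: the limit of > 1000 nM in this assay, at which 1 of the 4 values shown sits.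

The gap between compound 2 and compound 4 mixes two changes, the kind of group and its place on the phenyl ring, so 3-methoxyphenyl and 2-cyclopropylphenyl on this nitrogen are the obvious pair that could separate them. On these data alone, how an unsubstituted phenyl would read in this assay also remains open, and without it there is no baseline for judging what either the methoxy or the cyclopropyl group contributes.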